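From dimethylamino to trifluoromethoxy on the shared core

This account rests on a few compounds, and the source may have more. Where it says the series, first, only, none or still open, it means among the compounds named here.

- Compound 1 `Cc1ccc2nc(-c3ccccc3N(C)C)[nH]c(=O)c2c1`: > 50000 nM
- Compound 2 `Cc1ccc2c(=O)[nH]c(-c3ccccc3F)nc2c1`: 10300 nM

In a functional assay on HCT-15 cells (Homo sapiens) for cytotoxicity, read by MTT assay, with a stated time of 2 days (on this read-out lower numbers stand for stronger inhibition and higher numbers for weaker inhibition), compound 1 gives > 50000 nM, which is a limit of the assay and not a number. Compound 3 `Cc1ccc2nc(-c3ccccc3OC(F)(F)F)[nH]c(=O)c2c1` carries trifluoromethoxy in place of dimethylamino on an aromatic carbon. Among the compounds with values here, no measured pair differs in one place alone, so any expectation here remains loose. Within the data shown here, the only firm number comes from compound 2 at 10300 nM, so a moderate move toward stronger inhibition is expected for compound 3. The expected change is an at least 2.5-fold lower number from compound 1 to compound 3 (0.39 log units; beyond the scatter), an estimate that rests on that single number. For compound 3 the estimated value is 20000 nM, with an expected range from 6000 nM to 50000 nM.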

Compound 3, half-maximal inhibitory concentration: 2790 nM
Estimate against measurement, compound 3: 7.2-fold (0.86 log units) above; measured number outside the range, below it.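

In this assay, trifluoromethoxy in place of dimethylamino on an aromatic carbon, ortho to a large group, gives an at least 17-fold lower number from compound 1 to compound 3 (1.25 log units; beyond the scatter), so the read-out does respond to the group at this position. Compound 1 gives > 50000 nM, which is a limit of the assay and not a number. The true size of the step stays unknown because compound 1 stands at that limit: the limit of > 50000 nM in this assay, at which 1 of the 3 values shown sits.

The compounds shown leave open how methoxy or trifluoromethyl would read at this position. They therefore cannot separate the part played by the oxygen from that of the fluorines in trifluoromethoxy.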